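Exchanging the Sulfanyl Arm of Compound 2 for Compound 3

The compounds below may be only part of what the source reports. "The series", "measured", "known", "first", "only" and "open" are said of these compounds alone.

Measured compounds:
Compound 1 `COc1ccc(-n2c(SCc3ccc(C)cc3)nnc2-c2cc(OC)c(OC)c(OC)c2)cc1` in a functional assay on HCT-116 cells (Homo sapiens) for inhibition, read by MTT assay, with a stated time of 48 h; a lower number here means a stronger inhibitor, a higher number a weaker inhibitor: compound 1 gives 33300 nM.
Compound 2 `COc1cc(-c2nnc(SCc3ccc(C)cc3)n2-c2ccc(N(C)C)cc2)cc(OC)c1OC`: compound 2 gives > 60000 nM, which is a limit of the assay and not a number.

Of the two values shown, compound 1 has a measured number, while compound 2 sits at the limit of > 60000 nM in this assay, at which 1 of the 2 values shown sits, and is known only as a limit. Within the data shown here, the single measured step, an at least 1.8-fold higher number from compound 1 to compound 2 (0.25 log units; that floor lies within the scatter), came with dimethylamino in place of methoxy on an aromatic carbon, and its floor lies within the scatter.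

Compound 3 `CCOC(=O)CSc1nnc(-c2cc(OC)c(OC)c(OC)c2)n1-c1ccc(N(C)C)cc1` differs from compound 2 by ethoxycarbonyl in place of 4-methylphenyl on a saturated chain carbon bound to a sulfur. No measured step touches this sulfanyl arm; the one step shown concerns a different position, so it gives no direct guide. With compound 2 already at the limit, compound 3 is expected to remain in the same weak region. The step this estimate means, a step that the limit leaves unreadable from compound 2 to compound 3, is expected to stay within the scatter. Compound 3 is therefore estimated to give 70000 nM in this assay, with a range from 25000 nM to 200000 nM, and most likely again only a limit.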

Compound 3, half-maximal inhibitory concentration: > 60000 nM
Compound 3 ended at the assay's limit (the forecaster's own chance of this, stated with the estimate: 65%); the middle value lies beyond the limit too.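

In this assay compound 3 gives > 60000 nM as a limit of the assay and not a number. Among these compounds, compound 2 stands at the same limit, and no step between compound 2 and compound 3 can be read: the limit of > 60000 nM in this assay, at which 2 of the 3 values shown sit. The compounds shown leave open whether ethoxycarbonyl in place of 4-methylphenyl on a saturated chain carbon bound to a sulfur changes inhibition at all.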